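This account rests on a few compounds, and the source may have more. Where it says the series, first, only, none or still open, it means among the compounds named here.

In a functional assay on HUVEC cells (Homo sapiens) for inhibition, read by MTT assay, with a stated time of 3 days (on this read-out lower numbers stand for stronger inhibition and higher numbers for weaker inhibition), compound 2 `COc1cc([C@@H]2Oc3cc([C@H]4Oc5cc(OC(=O)c6cc(O)c(O)c(O)c6)cc(O)c5C(=O)[C@@H]4O)ccc3O[C@H]2CO)ccc1O` gives 4290 nM. This lies within the scatter of compound 1 `COc1cc(C2Oc3cc([C@H]4Oc5cc(OC(=O)c6cc(O)c(O)c(O)c6)cc(O)c5C(=O)[C@@H]4O)ccc3OC2CO)ccc1O` at 4750 nM, while compound 3 `COc1cc(C2Oc3cc([C@H]4Oc5cc(O)cc(O)c5C(=O)[C@@H]4OC(=O)c4cc(O)c(O)c(O)c4)ccc3OC2CO)ccc1O` reads higher at 12300 nM. Compound 4 `COc1cc([C@H]2Oc3cc([C@H]4Oc5cc(OC(=O)c6cc(O)c(O)c(O)c6)cc(O)c5C(=O)[C@@H]4O)ccc3O[C@@H]2CO)ccc1O` differs from compound 2 only in configuration as drawn: the two compounds have the same atoms and bonds and differ only in configuration as drawn: 2 of 4 stereo elements differ; a stereocentre at a saturated ring carbon is drawn S in compound 2 and R in compound 4; a stereocentre at a saturated ring carbon is drawn S in compound 2 and R in compound 4. Among the compounds with values here, the one measured step that bears on this change is a 1.1-fold lower number from compound 1 to compound 2 (0.04 log units; within the scatter), and it reflects only (the fact that one of compounds 1 and 2 is drawn with a defined configuration and the other without, at the place where they differ). That step does not compare S directly with R, so the evidence is indirect. Still, the small size of that step gives no ground to expect a large shift. In this assay, the estimated step stays within the scatter, at a 1.2-fold higher number from compound 2 to compound 4 (0.07 log units; within the scatter). The expected value for compound 4 is 5000 nM, with an estimated range of 2500 nM to 10000 nM.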

Compound 4, half-maximal inhibitory concentration: 6060 nM
Beside the measured number, compound 4's estimate is 1.2-fold (0.08 log units) below it, and the stated range covers the measured number.
By their numbers in this assay, from the lowest: compounds 2, 1 and 4 (each within the scatter of the next); then compound 3.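

Within the data shown here, compound 2 and compound 4 give the first direct comparison of S with R at the two saturated ring carbons in this assay, and the result is a 1.4-fold higher number from compound 2 to compound 4 (0.15 log units; within the scatter). Against compound 1, drawn without a configuration at these carbons, the result is a 1.3-fold higher number from compound 1 to compound 4 (0.11 log units; within the scatter). Neither drawn configuration therefore stands apart in this assay, and the comparison of compound 2 with compound 4 rests on a single kind of difference: the fact that compounds 2 and 4 differ only in the configuration as drawn

Going by these compounds, both carbons change together here, so the effect of either one alone stays open. Also open, on these data alone, is how an amine or a carboxylic acid on the shared core would read.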